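The source may hold more compounds than are shown below. What is called first, only, known or untested is meant among the compounds shown, and "the series" means these compounds.

Measured compounds:
compound 1 `COc1cc(N(Cc2ccc(Cl)cc2)S(=O)(=O)c2ccc(C)cc2)cc(OC)c1OC` with 1720 nM in a functional assay on MGC-803 cells (Homo sapiens) for inhibition, read by MTT assay, with a stated time of 48 h; a lower number here means a stronger inhibitor, a higher number a weaker inhibitor
compound 2 `COc1cc(N(Cc2nc3ccccc3[nH]2)S(=O)(=O)c2ccc(C)cc2)cc(OC)c1OC` with 1020 nM in this assay

Compound 2 stands at the lower of the two numbers, but its gap to compound 1, a 1.7-fold lower number from compound 1 to compound 2 (0.23 log units; within the scatter), lies within the scatter, so no order can be read between them. Compound 3 `COc1cc(N(Cc2nc3ccccc3[nH]2)C(=O)c2ccccc2)cc(OC)c1OC` is not yet measured in this assay. It differs from compound 2 by benzoyl in place of (4-methylphenyl)sulfonyl on a nitrogen on an aromatic ring. Among the measured compounds shown here, the single measured step, from compound 1 to compound 2, concerns the group on the saturated chain carbon bound to the sulfonamide nitrogen, not the group on the nitrogen itself, and it stayed within the scatter; it therefore gives no direction for the present change. For the measured compounds named here, no step bears on it. Compound 3 is accordingly expected to fall near compound 2, with a 1.2-fold higher number from compound 2 to compound 3 (0.07 log units; within the scatter) not beyond the scatter, and the estimate for compound 3 is 1200 nM, within 350 nM to 4500 nM.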

Compound 3, half-maximal inhibitory concentration: > 50000 nM
Compound 3: only a limit was reported; the forecaster's own chance of this, stated with the estimate: 8%; at least 41-fold (1.61 log units) between middle value and limit.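

Among the compounds shown here, on the nitrogen on an aromatic ring, the exchange of (4-methylphenyl)sulfonyl for benzoyl gives the first step in this assay that lies beyond the scatter: an at least 49-fold higher number from compound 2 to compound 3 (1.69 log units; beyond the scatter). The earlier compounds shown here varied only the group on the saturated chain carbon, and this step shows that the group on the nitrogen itself can weigh far more heavily, with benzoyl here no match for (4-methylphenyl)sulfonyl. The entry for compound 3, > 50000 nM, is a limit of the assay and not a number: the limit of > 50000 nM in this assay, at which 1 of the 3 values shown sits.

The compounds shown leave open whether the step follows from the carbonyl standing in place of the sulfonyl or from the missing methyl, which a 4-methylbenzoyl or a plain phenylsulfonyl group on this nitrogen would separate. Also open, on these data alone, is how a methanesulfonyl group, without any ring, would read here.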